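A few compounds are considered here, and "the series" means these few. Any claim that something is new, unique, unknown or untested is made for them only; others in the source may bear on it.

Measured in a functional assay (muscle tissue) with Cavia porcellus as the target; on this read-out higher numbers stand for an effect only at larger amounts of compound and lower numbers for an effect already at smaller amounts:
compound 1 `COC(=O)C1=C(C)N=C(C)/C(=C(\O)OC)C1c1cccc(OC)c1`: 191 nM
compound 2 `COC(=O)C1=C(C)N=C(C)/C(=C(\O)OC)C1c1ccccc1N`: 39800 nM
compound 3 `COC(=O)C1=C(C)N=C(C)/C(=C(\O)OC)C1c1ccc(F)cc1`: 129 nM

Compound 3 sits at the low end of the numbers in this assay: the step of a 1.5-fold lower number from compound 1 to compound 3 (0.17 log units; within the scatter) stays within the scatter, and the step of a 310-fold lower number from compound 2 to compound 3 (2.49 log units; beyond the scatter) is large.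

Compound 4 `COC(=O)C1=C(C)N=C(C)/C(=C(\O)OC)C1c1ccccc1I` carries 2-iodophenyl in place of 4-fluorophenyl on a saturated ring carbon.

Among the measured compounds shown here, no measured compound carries 2-iodophenyl, so the guidance is indirect. The exchange of 3-methoxyphenyl for 4-fluorophenyl stayed within the scatter, yet the large step of a 210-fold higher number from compound 1 to compound 2 (2.32 log units; beyond the scatter) shows that the aromatic group can matter greatly. Compound 2, with 2-aminophenyl, is the nearest match by name, but it is a weak guide, as one compound with a different group. A modest move toward a lower number is expected, with wide uncertainty.

The expected change is a 2.6-fold lower number from compound 3 to compound 4 (0.41 log units; beyond the scatter).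

For compound 4 the estimate is 50 nM, with an expected range of 8 nM to 300 nM.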

Compound 4, half-maximal effective concentration: 46.8 nM
Compound 4: middle estimate off by 1.1-fold (0.03 log units), on the high side, within the range that was stated.
By their numbers in this assay, from the lowest: compound 4; then compounds 3 and 1 (each within the scatter of the next); then compound 2.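

In this assay the 2-iodophenyl group of compound 4 gives the lowest number of the series, with a 2.8-fold lower number from compound 3 to compound 4 (0.44 log units; beyond the scatter) and a 4.1-fold lower number from compound 1 to compound 4 (0.61 log units; beyond the scatter) as modest steps. The aromatic group on this saturated ring carbon can therefore lower the number beyond the scatter, which the exchange between the 3-methoxyphenyl and 4-fluorophenyl groups did not show. Iodo in place of amino on the same aromatic carbon gives an 850-fold lower number from compound 2 to compound 4 (2.93 log units; beyond the scatter), so the high number of compound 2 does not extend to every 2-substituted phenyl group.

The compounds shown leave open whether a 2-bromophenyl or 2-methylphenyl group would stay close to compound 4, and whether a 4-iodophenyl group would match it. Nothing at hand gives a reason for these steps.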